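The source may report more compounds than this note shows. Statements on the series, on what has been measured and on what is new or still open speak of the compounds shown alone.

Measured so far:
- compound 1, `O=C(CN1CCNCC1)N1CCC(NS(=O)(=O)c2cc(S(=O)(=O)c3ccccc3)ccc2C(F)(F)F)CC1`: 250 nM
- compound 2, `CC(C)(C)OC(=O)N1C(=O)CC[C@H]1C(=O)N1CCC(NS(=O)(=O)c2cc(S(=O)(=O)c3ccccc3)ccc2C(F)(F)F)CC1`: 90 nM

Of the compounds shown here, two sharing the same core have been measured in a functional assay on U2OS cells for antagonist activity at proto-oncogene Wnt-3 (Homo sapiens), read by a luciferase reporter, with a stated time of 18 h; a higher number here means that more compound is needed for the effect, a lower number that less compound is needed. Compound 1 gives 250 nM and stands highest of the two numbers; compound 2 gives 90 nM, the nearer and only comparison, a gap beyond the scatter. Among the measured compounds shown here, no step between measured compounds that differ in one place is available, so compound 3 is judged from the change itself and from where compound 1 stands.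

Compound 3, `O=C1CC[C@@H](C(=O)N2CCC(NS(=O)(=O)c3cc(S(=O)(=O)c4ccccc4)ccc3C(F)(F)F)CC2)N1`, has not yet been measured in this assay. Its difference from compound 1 is 5-oxopyrrolidin-2-yl in place of (piperazin-1-yl)methyl on a carbonyl carbon. Both the leaving and the entering group keep one hydrogen-bond donor; the entering group is the smaller of the two and brings a defined stereocentre.

With compound 2 below compound 1, the series gives no sign of a rise; the step of a 1.9-fold lower number from compound 1 to compound 3 (0.28 log units; within the scatter) is expected to be a modest fall, at or just beyond the scatter. For compound 3 in this assay the estimate is 130 nM, with a range from 50 nM to 320 nM.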

Compound 3, half-maximal effective concentration: 240 nM
The estimate for compound 3 lay 1.8-fold (0.27 log units) below the measured number, and the stated range covers the measured number.
By their numbers in this assay, from the lowest: compound 2; then compounds 3 and 1 (each within the scatter of the next).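

In this assay the exchange of (piperazin-1-yl)methyl for 5-oxopyrrolidin-2-yl on a carbonyl carbon gives a 1.0-fold lower number from compound 1 to compound 3 (0.02 log units; within the scatter) and so shows that this read-out does not separate these two groups at this position, although they differ in ring size and the entering group carries a defined stereocentre. Hydrogen in place of tert-butoxycarbonyl on an amide-type nitrogen in a ring gives a 2.7-fold higher number from compound 2 to compound 3 (0.43 log units; beyond the scatter) and is the only step here beyond the scatter, so among these three compounds the clear difference lies at that nitrogen, not in the exchange on the carbonyl carbon. No other measurement is available to account for either step.

Going by these compounds, whether the step at that nitrogen depends on the size of the group stays open, since nothing lies between hydrogen and tert-butoxycarbonyl, such as a methyl or an acetyl group. Also open, on these data alone, are the opposite configuration at the stereocentre and whether an open-chain amine or a carboxylic acid on the carbonyl carbon would read like the two rings.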